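The source may report more compounds than this note shows. Statements on the series, on what has been measured and on what is new or still open speak of the compounds shown alone.

Working notes on the series in an assay on CHO cells for displacement of a labelled ligand from Alpha-1B adrenergic receptor (Homo sapiens); on this read-out lower numbers stand for stronger inhibition and higher numbers for weaker inhibition. Compound 1 `COc1cccc(OC)c1OCCNCCOc1ccccc1OCc1cccc(C)c1` gives 0.251 nM. Among the compounds with values here, compound 2 `COc1ccccc1COc1ccccc1OCCNCCOc1c(OC)cccc1OC` gives 6.31 nM; the one change, 2-methoxyphenyl in place of 3-methylphenyl on a saturated chain carbon bound to an oxygen on an aromatic ring, produced a 25-fold higher number from compound 1 to compound 2 (1.40 log units; beyond the scatter). Within the data shown here, on the two numbers to hand compound 2 stands highest, compound 1 being its only neighbour.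

Compound 3 `COc1ccc(COc2ccccc2OCCNCCOc2c(OC)cccc2OC)cc1` carries the change (4-methoxyphenyl in place of 2-methoxyphenyl on a saturated chain carbon bound to an oxygen on an aromatic ring). Among the measured compounds shown here, no measured step moves a methoxy group around this ring; the only step that touches the same position, a 25-fold higher number from compound 1 to compound 2 (1.40 log units; beyond the scatter), shows that the group on this saturated chain carbon can shift this assay strongly, but it does not fix the direction for the present change. A lowering is expected for compound 3, to be read as a moderate step of a 2.5-fold lower number from compound 2 to compound 3 (0.40 log units; beyond the scatter) and held with wide bounds. The estimate for compound 3 is therefore 2.5 nM, with a range from 0.5 nM to 12 nM.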

Compound 3, inhibition constant: 0.398 nM
Compound 3: middle estimate off by 6.3-fold (0.80 log units), on the high side, and the stated range ends above it.
By their numbers in this assay, from the lowest: compounds 1 and 3 (each within the scatter of the next); then compound 2.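

In this assay, the same atoms joined differently give a 16-fold lower number from compound 2 to compound 3 (1.20 log units; beyond the scatter), so the place of the methoxy group on this ring can alone carry a large step, which the earlier change of group could not separate out. Replacing 3-methylphenyl with 4-methoxyphenyl gives a 1.6-fold higher number from compound 1 to compound 3 (0.20 log units; within the scatter), so these two groups are not told apart on this read-out, and among the three compounds only the 2-methoxyphenyl of compound 2 stands apart, beyond the scatter from both others. No supporting data bear on why the methoxy placement matters here.

The compounds shown leave open how an amine or a carboxylic acid in place of the methoxy group would read. From the compounds shown here alone, whether the large step survives on a longer chain at this position also remains open.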